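A Benzylamine Replaces the Amide on the Shared Core

The source may report more compounds than this note shows. Statements on the series, on what has been measured and on what is new or still open speak of the compounds shown alone.

Compound 1 `CC(C)c1onc(-c2c(Cl)cccc2Cl)c1COc1ccc(N(C)C(=O)c2cccc(C(=O)O)c2)c(C(F)(F)F)n1` sits at the top of the three numbers gathered so far. In an assay on isolated protein for agonist activity at Bile acid receptor (Homo sapiens), read by FRET (a higher number here means that more compound is needed for the effect, a lower number that less compound is needed), compound 1 gives 433 nM. Compound 2 `Cc1cc(OCc2c(-c3c(Cl)cccc3Cl)noc2C(C)C)ncc1[N+](=O)[O-]` gives 89 nM in this assay, and compound 3 `CC(C)c1onc(-c2c(Cl)cccc2Cl)c1COc1ccc(NCc2ccc(C(=O)O)cc2)c(C(F)(F)F)n1` gives 162 nM, so both stand beyond the scatter from compound 1, compound 3 nearer and compound 2 furthest away. Compound 4 `CC(C)c1onc(-c2c(Cl)cccc2Cl)c1COc1ccc(N(C)Cc2ccc(OCC(=O)O)cc2)c(C(F)(F)F)n1` has not yet been measured. Relative to compound 1, the change is 4-(carboxymethoxy)benzyl in place of (3-carboxyphenyl)carbonyl on a nitrogen on an aromatic ring. Going by the values given here, no step between measured compounds that differ in one place has been recorded, so the direction of this change rests on what compound 3 shows: compound 3 also carries a benzyl group rather than a carbonyl on that nitrogen, and compound 3 with its value 162 nM sits lower than compound 1. Compound 4 is therefore expected to need less compound than compound 1, with a step of a 2.9-fold lower number from compound 1 to compound 4 (0.46 log units; beyond the scatter) toward a lower number, although compound 3 differs from compound 4 in more than one place, so this expectation is held loosely. The estimate for compound 4 is 150 nM, within a range from 60 nM to 400 nM.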

Compound 4, half-maximal effective concentration: 35 nM
Beside the measured number, compound 4's estimate is 4.3-fold (0.63 log units) above it; the whole stated range lies above it.
By their numbers in this assay, from the lowest: compound 4; then compounds 2 and 3 (each within the scatter of the next); then compound 1.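

Going by these compounds alone, the step of a 12-fold lower number from compound 1 to compound 4 (1.09 log units; beyond the scatter) in this assay is the first recorded between two measured compounds that differ in one place. It shows that the group on a nitrogen on an aromatic ring can shift the number by a large margin when 4-(carboxymethoxy)benzyl takes the place of (3-carboxyphenyl)carbonyl, even though the entering and leaving groups each hold one six-membered aromatic ring of carbon only and the same counts of hydrogen-bond donors and acceptors. Nothing available accounts for the size of this step.

This one change replaces the carbonyl with a benzyl group, alters where the carboxylic acid sits on the ring and inserts a carboxymethoxy chain all at once, so the compounds shown cannot separate the share of each in the step. They also leave open how the number responds when a tetrazole takes the place of the carboxylic acid, or when a longer chain carries that acid on the benzyl group.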